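A few compounds are considered here, and "the series" means these few. Any claim that something is new, unique, unknown or untested is made for them only; others in the source may bear on it.

Working notes on the series.

Compound 1 `CCCN(CC1CC1)c1nc(C)nc(Nc2c(Cl)cc(Cl)cc2Cl)c1C` is the reference point. In an assay on isolated protein for binding affinity to corticotropin-releasing factor receptor 1 (Homo sapiens) (a higher number here means a weaker inhibitor, a lower number a stronger inhibitor), compound 1 gives 2.3 nM. Going by the values given here, the only other measured member, compound 2 `CCCN(CC1CC1)c1nc(C)nc(Nc2c(Cl)cc(Cl)cc2Cl)c1CC`, gives 3.8 nM in this assay; the step of a 1.7-fold higher number from compound 1 to compound 2 (0.22 log units; within the scatter) is within the scatter, so compound 1 and compound 2 are not separated by these numbers, and compound 1 simply stands at one end of a pair that the assay does not distinguish.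

Compound 3 `CCCN(CCC)c1nc(C)nc(Nc2c(Cl)cc(Cl)cc2Cl)c1C` differs from compound 1 in one place: ethyl in place of cyclopropyl on a saturated chain carbon bound to a nitrogen on an aromatic ring. Among the compounds with values here, no measured step in the set bears on this change. Within the data shown here, the single step on record, a 1.7-fold higher number from compound 1 to compound 2 (0.22 log units; within the scatter), concerns a different position, the saturated chain carbon bound to an aromatic carbon, and says nothing about the substituent on the nitrogen. Among the measured compounds shown here, the data therefore give no direction for the change from cyclopropyl to ethyl; the only guidance is that the one alteration tried so far, a small change at the periphery of the shared core, moved the number within the scatter.

On that basis compound 3 is expected to give 4 nM in this assay, with a range of 1.5 nM to 12 nM, meaning an expected step of a 1.7-fold higher number from compound 1 to compound 3 (0.24 log units; within the scatter) of no clear size beyond the scatter.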

Compound 3, inhibition constant: 2.5 nM
Compound 3: middle estimate off by 1.6-fold (0.20 log units), on the high side; the range from low to high includes it.
By their numbers in this assay, from the lowest: compounds 1, 3 and 2 (each within the scatter of the next).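

Ethyl in place of cyclopropyl on a saturated chain carbon bound to a nitrogen on an aromatic ring is the first change on record at this position, and in this assay it gives a step of a 1.1-fold higher number from compound 1 to compound 3 (0.04 log units; within the scatter). The earlier pair spoke only to the saturated chain carbon bound to an aromatic carbon; this pair shows that, with the rest of compound 1 held fixed, going from cyclopropylmethyl to propyl removes the three-membered ring without separating the two numbers, so for this pair the ring is not required to keep the number in the range of compound 1. Nothing on record gives a reason for this result.

The one change at this position stays among small saturated carbon groups, so the compounds shown leave open whether a longer chain such as butyl, or a methoxyethyl group, would still leave the number within the scatter. They also leave open whether a chain ending in an amine or a carboxylic acid at the same place would move the number beyond it.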